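The source may hold more compounds than are shown below. What is called first, only, known or untested is meant among the compounds shown, and "the series" means these compounds.

Measured in a functional assay on LNCaP cells (Homo sapiens) for antiproliferative activity, read by propidium iodide staining, with a stated time of 96 h; a lower number here means a stronger inhibitor, a higher number a weaker inhibitor:
- compound 1 `CC(O)(CS(=O)(=O)c1ccc(F)cc1)C(=O)Nc1cccc(S(F)(F)(F)(F)F)c1`: 32600 nM
- compound 2 `CC(O)(CS(=O)(=O)c1cccc(C(F)(F)F)c1)C(=O)Nc1cccc(S(F)(F)(F)(F)F)c1`: 21800 nM
- compound 3 `CC(O)(CS(=O)(=O)c1cccc(OC(F)(F)F)c1)C(=O)Nc1cccc(S(F)(F)(F)(F)F)c1`: 15100 nM

Compound 3, at 15100 nM, has the lowest number of the three, but only compound 1 is separated from it beyond the scatter, by a 2.2-fold lower number from compound 1 to compound 3 (0.33 log units; beyond the scatter). Compound 2 cannot be told apart from compound 3, as a 1.4-fold lower number from compound 2 to compound 3 (0.16 log units; within the scatter) shows.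

The next compound is compound 4 `CC(O)(CS(=O)(=O)c1ccccc1OC(F)(F)F)C(=O)Nc1cccc(S(F)(F)(F)(F)F)c1`. It has the same atoms as compound 3, joined differently: 2-(trifluoromethoxy)phenyl in place of 3-(trifluoromethoxy)phenyl on a sulfonyl sulfur. The group sits on a sulfonyl sulfur whose other neighbour is a saturated chain carbon.

For the measured compounds named here, no measured step shows what this kind of shift does on its own. The nearest evidence is the other changes to the group on the sulfonyl sulfur: a 1.5-fold lower number from compound 1 to compound 2 (0.17 log units; within the scatter), a 2.2-fold lower number from compound 1 to compound 3 (0.33 log units; beyond the scatter) and a 1.4-fold lower number from compound 2 to compound 3 (0.16 log units; within the scatter). Going by the values given here, all three are small, and only the step to compound 3 from compound 1 clears the scatter, and only modestly. On that basis, no step beyond the scatter is expected in this assay, and the data fix no firm direction. The expected step is a 1.3-fold higher number from compound 3 to compound 4 (0.12 log units; within the scatter). For compound 4 the estimated value is 20000 nM, with an expected range from 10000 nM to 40000 nM.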

Compound 4, half-maximal inhibitory concentration: 9000 nM
Beside the measured number, compound 4's estimate is 2.2-fold (0.35 log units) above it; measured number below the stated range.
By their numbers in this assay, from the lowest: compounds 4, 3, 2 and 1 (each within the scatter of the next, the first and the last beyond it).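

In this assay, for the compounds shown here, this isomer pair is the first view of what moving the trifluoromethoxy group does on its own: 2-(trifluoromethoxy)phenyl in place of 3-(trifluoromethoxy)phenyl on a sulfonyl sulfur gives a 1.7-fold lower number from compound 3 to compound 4 (0.22 log units; within the scatter), so the shift does not separate the two compounds. What is new lies in the comparisons with the other groups at this position: compound 4 stands apart from compound 2, with a 2.4-fold lower number from compound 2 to compound 4 (0.38 log units; beyond the scatter), a separation that compound 3 did not reach against compound 2, and it also stands apart from compound 1, with a 3.6-fold lower number from compound 1 to compound 4 (0.56 log units; beyond the scatter), although both steps remain modest. Nothing available explains these differences.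

As far as these compounds go, the trifluoromethoxy group is the only one seen at two places on this aromatic ring, so it remains open whether a methoxy group or a chlorine atom would respond in the same way to the same shift. From the compounds shown here alone, it is also open how the numbers would change if an amine or a carboxylic acid were carried on that ring.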